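Solubility of a fused core: from cyanopentyl to hydroxymethyl-thiazolyl

The compounds below may be only part of what the source reports. "The series", "measured", "known", "first", "only" and "open" are said of these compounds alone.

Measured compounds:
compound 1, `N#Cc1c(N)nc2nc(C3CCC3)ncc2c1N`, 217000 nM
compound 2, `CC(C)Cc1ncc2c(N)c(C#N)c(N)nc2n1`, 268000 nM
compound 3, `CC(C)(C)c1nc(CCCCCC#N)c2c(N)c(C#N)c(N)nc2n1`, 6000 nM

Of the compounds shown here, three sharing one fused core have been measured in a physicochemical assay for solubility, in phosphate buffer, with a stated time of 18 h; on this read-out lower numbers stand for lower solubility and higher numbers for higher solubility. Compound 3 stands lowest of the three, and its distance to both compound 1 and compound 2 lies beyond the usual scatter. Compound 4 is `CC(C)(C)c1nc(-c2nc(CO)cs2)c2c(N)c(C#N)c(N)nc2n1`, and it has not yet been measured in this assay. It differs from compound 3 in one place: 4-(hydroxymethyl)-1,3-thiazol-2-yl in place of 5-cyanopentyl on an aromatic carbon.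

Among the compounds with values here, only one measured step joins two compounds that differ in a single place, and it is a 1.2-fold higher number from compound 1 to compound 2 (0.09 log units; within the scatter). That step exchanges one alkyl group for another on an aromatic carbon and therefore bears only loosely on the present change, in which a chain carrying a nitrile gives way to a five-membered aromatic ring carrying a hydroxymethyl group. Within the data shown here, no measured pair tests such an exchange directly. With only the small step from compound 1 to compound 2 as a guide, a moderate step is expected for compound 4, a 1.3-fold higher number from compound 3 to compound 4 (0.12 log units; within the scatter), with the direction uncertain. Compound 4 is therefore estimated to give 8000 nM in this assay, within a range from 2000 nM to 30000 nM.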

Compound 4, solubility: < 1000 nM
Compound 4: only a limit was reported; the forecaster's own chance of this, stated with the estimate: 5%; middle value at least 8.0-fold (0.90 log units) away from the limit.
By their numbers in this assay, from the lowest: compound 3; then compounds 1 and 2 (each within the scatter of the next). At a limit, below all of these: compound 4.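

In this assay, replacing 5-cyanopentyl with 4-(hydroxymethyl)-1,3-thiazol-2-yl on the aromatic carbon meta to a tert-butyl group gives an at least 6.0-fold lower number from compound 3 to compound 4 (0.77 log units; beyond the scatter), a step beyond the scatter. Within the data shown here, for compound 4, the reported < 1000 nM is a limit of the assay and not a number, so the step has a minimum size but no exact size: the limit of < 1000 nM in this assay, at which 1 of the 4 values shown sits. The only earlier step, a 1.2-fold higher number from compound 1 to compound 2 (0.09 log units; within the scatter), exchanged one alkyl group for another and stayed within the scatter, whereas this exchange shows a clear difference between two groups with the same heavy-atom count, one an open chain with a nitrile and the other a five-membered aromatic ring with a hydroxymethyl group.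

The compounds shown leave open how far compound 4 lies beneath its limit, and whether the step follows the aromatic ring, the hydroxymethyl group or the loss of the nitrile. A plain thiazol-2-yl group, a pentyl chain ending in a hydroxyl group or an amine, or a phenyl ring carrying hydroxymethyl at this place would separate those parts.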